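The compounds below may be only part of what the source reports. "The series", "measured", "known", "first", "only" and "open" are said of these compounds alone.

Compound 1 `Fc1ccc(C2CC(c3ccccc3)=NN2c2ccc(-c3ccccc3)nn2)cc1` and compound 3 `COc1ccc(C2=NN(c3ccc(-c4ccccc4)nn3)C(c3ccc(F)cc3)C2)cc1` differ only at the shared core, where (methoxy in place of hydrogen on an aromatic carbon). In a functional assay on HepG2 cells (Homo sapiens) for antiproliferative activity, read by MTT assay, with a stated time of 24 h (on this read-out higher numbers stand for weaker inhibition and lower numbers for stronger inhibition), compound 1 gives 8420 nM, and compound 3 gives 9160 nM; between them a 1.1-fold higher number from compound 1 to compound 3 (0.04 log units; within the scatter). Compound 2 `FC(F)(F)c1ccc(C2CC(c3ccccc3)=NN2c2ccc(-c3ccccc3)nn2)cc1` is derived from compound 1 by the change (trifluoromethyl in place of fluoro on an aromatic carbon). In this assay compound 2 gives 10000 nM, so that a 1.2-fold higher number from compound 1 to compound 2 (0.07 log units; within the scatter). Compound 4 `COc1ccc(C2=NN(c3ccc(-c4ccccc4)nn3)C(c3ccc(C(F)(F)F)cc3)C2)cc1` has not yet been measured; it stands to compound 3 as compound 2 stands to compound 1, the difference being (trifluoromethyl in place of fluoro on an aromatic carbon). The place of the change is described in the same words in both pairs, so it is the same change made on two cores that differ as described above. The step from compound 3 to compound 4 in this assay is expected to be a 1.1-fold higher number from compound 3 to compound 4 (0.06 log units; within the scatter). This expectation rests on the measured pair, where a 1.2-fold higher number from compound 1 to compound 2 (0.07 log units; within the scatter). Compound 4 is therefore estimated to give 10500 nM in this assay, with a likely range from 5000 nM to 22000 nM.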

Compound 4, half-maximal inhibitory concentration: > 100000 nM
Compound 4: only a limit was reported; the forecaster's own chance of this, stated with the estimate: 25%; middle value at least 9.5-fold (0.97 log units) from the limit.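

Trifluoromethyl in place of fluoro does not carry over unchanged between the two cores, the step on the methoxy-bearing core being an at least 10-fold higher number from compound 3 to compound 4 (1.03 log units; beyond the scatter): the same change on two cores in this assay, a 1.2-fold higher number (0.07 log units; within the scatter) from compound 1 to compound 2 and an at least 10-fold higher number (1.03 log units; beyond the scatter) from compound 3 to compound 4, at least 9.1-fold (0.96 log units) apart, beyond the scatter of two such steps Methoxy in place of hydrogen likewise behaves differently on the two cores, the step on the trifluoromethyl-bearing core being an at least 10-fold higher number from compound 2 to compound 4 (1.00 log units; beyond the scatter): the same change on two cores in this assay, a 1.1-fold higher number (0.04 log units; within the scatter) from compound 1 to compound 3 and an at least 10-fold higher number (1.00 log units; beyond the scatter) from compound 2 to compound 4, at least 9.1-fold (0.96 log units) apart, beyond the scatter of two such steps In this assay compound 4 is reported only as a limit, > 100000 nM, so the data fix neither step's exact size, and they show that the two changes do not act independently in this set of four compounds without showing why.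

The series shown pairs methoxy only with fluoro and trifluoromethyl, so it remains open whether a chloro group, a nitrile or an amine on the same aromatic carbon would be tolerated alongside methoxy. As far as these compounds go, it also remains open whether another group in place of methoxy, such as a hydroxyl or an ethoxy group, would give the same result with trifluoromethyl.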